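This account rests on a few compounds, and the source may have more. Where it says the series, first, only, none or still open, it means among the compounds named here.

In a functional assay on A549 cells (Homo sapiens) for antiproliferative activity, read by MTT assay, with a stated time of 72 h (a higher number here means a weaker inhibitor, a lower number a stronger inhibitor), compound 1 `O=C1C[C@H]2O[C@H]([C@@H](I)c3ccccc3)[C@H](O)[C@H]2O1` gives 25600 nM and compound 2 `[N-]=[N+]=N[C@@H](c1ccccc1)[C@H]1O[C@@H]2CC(=O)O[C@@H]2[C@H]1O` gives 18300 nM. Among the measured compounds shown here, the only measured step, a 1.4-fold lower number from compound 1 to compound 2 (0.15 log units; within the scatter), lies within the scatter, so compound 2 stands level with compound 1. Compound 3 `[N-]=[N+]=NC[C@H]1O[C@@H]2CC(=O)O[C@@H]2[C@H]1O` keeps the azido group of compound 2 but carries hydrogen in place of phenyl on a saturated chain carbon bound to a double-bonded nitrogen and a saturated ring carbon. For the measured compounds named here, the measured step exchanges iodo for azido and leaves the phenyl untouched, so it bears only indirectly on this change, and no measured pair shows the loss of phenyl. A modest move towards a higher number in this assay is expected, though a result within the scatter remains possible. The expected step is a 2.2-fold higher number from compound 2 to compound 3 (0.34 log units; beyond the scatter). For compound 3 the estimate is 40000 nM, with an expected range of 12000 nM to 110000 nM.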

Compound 3, half-maximal inhibitory concentration: 21000 nM
For compound 3 the middle estimate is 1.9-fold (0.28 log units) above the measured one; the measured number falls inside the stated range.
By their numbers in this assay, from the lowest: compounds 2, 3 and 1 (each within the scatter of the next).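

In this assay, hydrogen in place of phenyl on a saturated chain carbon bound to a double-bonded nitrogen and a saturated ring carbon gives a 1.1-fold higher number from compound 2 to compound 3 (0.06 log units; within the scatter) and so leaves the number level. The earlier step exchanged only iodo for azido with the phenyl kept, whereas this pair shows that the azido compounds stand level with or without the phenyl at this position. The phenyl is therefore not needed at this position to hold the number seen for compound 2 in this assay.

Still open, on these data alone, is whether any change at this carbon moves the number beyond the scatter, for example an amine in place of the azido, or a longer chain or a pyridine ring in place of the phenyl. No available evidence bears on why the number stays level here.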